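A fluorine moved on the phenyl group

This account rests on a few compounds, and the source may have more. Where it says the series, first, only, none or still open, it means among the compounds named here.

In a functional assay on MM1 cells (Homo sapiens) for antiproliferative activity, read by MTT assay, with a stated time of 72 h (a lower number here means a stronger inhibitor, a higher number a weaker inhibitor), compound 1 `COc1cccc([C@H](C)NC(=O)/C(C#N)=C/c2cccc(Br)n2)c1` gives 2400 nM and compound 2 `C[C@H](NC(=O)/C(C#N)=C/c1cccc(Br)n1)c1ccc(F)cc1` gives 1200 nM so these two stand level within the scatter. Compound 3 `C[C@H](NC(=O)/C(C#N)=C/c1cccc(Br)n1)c1ccccc1F` has the same atoms as compound 2 joined differently: 2-fluorophenyl in place of 4-fluorophenyl on a saturated chain carbon bound to an amide-type nitrogen and a saturated chain carbon with 2-fluorophenyl in place of 4-fluorophenyl. Among the compounds with values here, the one measured step at this place is a 2.0-fold lower number from compound 1 to compound 2 (0.30 log units; within the scatter) and it stayed within the scatter, so no step beyond the scatter is expected in this assay for this change. The estimated step is a 1.3-fold higher number from compound 2 to compound 3 (0.10 log units; within the scatter) and it also stays within the scatter. Compound 3 is expected near 1500 nM with an estimated range from 600 nM to 3500 nM in this measurement.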

Compound 3, half-maximal inhibitory concentration: 1800 nM
Compound 3: middle estimate off by 1.2-fold (0.08 log units), on the low side; the range from low to high includes it.
By their numbers in this assay, from the lowest: compounds 2, 3 and 1 (each within the scatter of the next).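

Moving the fluorine gives a 1.5-fold higher number from compound 2 to compound 3 (0.18 log units; within the scatter) in this assay, so 2-fluorophenyl and 4-fluorophenyl stand level at this place. Compared with 3-methoxyphenyl, 2-fluorophenyl gives a 1.3-fold lower number from compound 1 to compound 3 (0.12 log units; within the scatter) and also stands level, so none of the three phenyl groups shown here is separated from the others by a step beyond the scatter. Nothing measured here speaks to the reason for this.

Still open, on these data alone, is how 3-fluorophenyl would compare with these groups. Also open, as far as these compounds go, is whether an amine or a carboxylic acid in place of the fluorine would give a step beyond the scatter.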